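Phenyl for chlorobenzyl on the triazole nitrogen

The compounds below may be only part of what the source reports. "The series", "measured", "known", "first", "only" and "open" are said of these compounds alone.

Compound 1, `COc1ccc(C[C@H]2COC(=O)[C@@H]2Cc2ccc(OCc3cn(Cc4ccc(Cl)cc4)nn3)c(OC)c2)cc1OC`: 242000 nM
Compound 2, `COc1ccc(C[C@H]2COC(=O)[C@@H]2Cc2ccc(OC(=O)CCC(=O)N3CCCC3)c(OC)c2)cc1OC`: 201000 nM
Compound 3, `COc1ccc(-n2cc(COc3ccc(C[C@H]4C(=O)OC[C@@H]4Cc4ccc(OC)c(OC)c4)cc3OC)nn2)cc1`: a limit, >= 600000 nM

In an ADME assay on HeLa cells (Homo sapiens) for cytotoxicity, read by MTT assay (on this read-out higher numbers stand for weaker inhibition and lower numbers for stronger inhibition), compound 1 gives 242000 nM. Compound 2 gives 201000 nM, and the two values sit within the scatter of each other, so no order between them can be read. Compound 3 gives only a limit in this assay, >= 600000 nM. Among the compounds with values here, the one measured step that changes the group on the aromatic nitrogen, an at least 2.4-fold higher number from compound 1 to compound 3 (0.39 log units; beyond the scatter), is bounded on one side by the limit described in the limit of >= 600000 nM in this assay, at which 1 of the 3 values shown sits.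

Compound 4, `COc1ccc(C[C@H]2COC(=O)[C@@H]2Cc2ccc(OCc3cn(-c4ccccc4)nn3)c(OC)c2)cc1OC`, differs from compound 1 by phenyl in place of 4-chlorobenzyl on an aromatic nitrogen. The step from compound 1 to compound 3 likewise removed the 4-chlorobenzyl group in favour of an aryl group set directly on the aromatic nitrogen, and it moved the number up, at least modestly. A step of similar direction is therefore expected here, with a fair chance that compound 4 also reaches the limit rather than a number. Compound 4 is expected to give about 450000 nM, within 200000 nM to 900000 nM, an estimated step of a 1.9-fold higher number from compound 1 to compound 4 (0.27 log units; within the scatter).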

Compound 4, half-maximal inhibitory concentration: 124000 nM
The estimate for compound 4 lay 3.6-fold (0.56 log units) above the measured number; measured number outside the range, below it.
By their numbers in this assay, from the lowest: compounds 4, 2 and 1 (each within the scatter of the next). At a limit, above all of these: compound 3.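

In this assay, phenyl in place of 4-chlorobenzyl on the triazole nitrogen gives a 2.0-fold lower number from compound 1 to compound 4 (0.29 log units; within the scatter), so an aryl group set directly on that nitrogen does not by itself produce the rise seen with 4-methoxyphenyl. The methoxy group on the aromatic carbon marks the clearer difference: hydrogen in its place gives an at least 4.8-fold lower number from compound 3 to compound 4 (0.68 log units; beyond the scatter). The group on the oxygen of the aromatic ring can also differ widely without a readable change, with a 1.6-fold lower number from compound 2 to compound 4 (0.21 log units; within the scatter).

As far as these compounds go, compound 3 gives only a limit, so the full size of the step to compound 4 stays open: the limit of >= 600000 nM in this assay, at which 1 of the 4 values shown sits. From the compounds shown here alone, whether an amine or a carboxylic acid on that aromatic carbon would read like hydrogen or like methoxy also stays open.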